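The compounds below may be only part of what the source reports. "The series", "measured", "known", "first", "only" and "open" are said of these compounds alone.

Working notes on the series.

Compound 1 `Cc1ccc(-n2nc(-c3ccc(C(F)(F)F)cc3O)nc2-c2ccccc2O)cc1` is the stronger of the two measured compounds: in a functional assay on PC-12 cells (Rattus norvegicus) for cytotoxicity, read by MTT assay, with stated times of 2 h and 24 h, tested at 10 uM (a higher number here means a stronger effect of the compound at the concentration tested, a lower number a weaker effect), compound 1 gives 102%, the highest of the two numbers in hand. Among the compounds with values here, compound 2 `CC(C)(C)c1ccc(-n2nc(-c3ccc(C(F)(F)F)cc3O)nc2-c2ccccc2O)cc1` gives 81.1% in this assay, and the one measured step, tert-butyl in place of methyl on an aromatic carbon, is a number 20.9 percentage points lower from compound 1 to compound 2 (beyond the scatter).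

Compound 3 `Oc1cc(C(F)(F)F)ccc1-c1nc(-c2ccccc2O)n(-c2cc(F)cc(F)c2)n1` is not yet measured. It differs from compound 1 by 3,5-difluorophenyl in place of 4-methylphenyl on an aromatic nitrogen. The measured step from compound 1 to compound 2 alters the same group that is exchanged here, the phenyl on the aromatic nitrogen, and it lowered the number modestly while the rest of the shared core stayed fixed. Within the data shown here, that step changes a substituent on that phenyl, whereas the change to compound 3 replaces the whole 4-methylphenyl with 3,5-difluorophenyl; the only precedent therefore points to a small drop or to no change beyond the scatter.

Compound 3 is expected to show a step of a number 12 percentage points lower from compound 1 to compound 3 (beyond the scatter) in this assay, estimated at 90% with a range from 65% to 110%.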

Compound 3, a percentage reported as activity, at one concentration (the size of the read-out at that concentration, not a potency): 106%
Compound 3: middle estimate off by 16 percentage points, on the low side; the range from low to high includes it.
By their numbers in this assay, from the lowest: compound 2; then compounds 1 and 3 (each within the scatter of the next).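

In this assay the exchange of 4-methylphenyl for 3,5-difluorophenyl on the aromatic nitrogen gives a number 4 percentage points higher from compound 1 to compound 3 (within the scatter) and so shows that the whole phenyl substituent pattern at this position can change without a difference that can be told from the scatter. Set against the 4-(tert-butyl)phenyl group, the same 3,5-difluorophenyl group gives a number 24.9 percentage points higher from compound 2 to compound 3 (beyond the scatter) and leaves compound 2 as the only one of the three set apart, while compounds 1 and 3 read alike. The earlier drop therefore belongs to the 4-(tert-butyl)phenyl group specifically and is not a general result of altering this phenyl, though three compounds carry that reading no further than themselves. No measurement shown here bears on the reason for this pattern.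

As far as these compounds go, all three compounds carry a substituted phenyl on the aromatic nitrogen, so it remains open whether a phenyl bearing an amine or a carboxylic acid, or a cyclohexyl group in place of the phenyl, would keep the number of compounds 1 and 3 or fall as compound 2 does. From the compounds shown here alone, these are also readings at a single concentration, so how the compounds compare across a range of concentrations remains open.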